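A Fluoro Added to Compound 1: Expected Cytotoxicity

The source may hold more compounds than are shown below. What is called first, only, known or untested is meant among the compounds shown, and "the series" means these compounds.

Compound 1 `N=C(NO)c1ccc(-c2ccc(-c3ccc(/C(N)=N\O)cc3)cc2)cc1` was tested in a functional assay on L6 cells (Rattus norvegicus) for cytotoxicity; on this read-out lower numbers stand for stronger inhibition and higher numbers for weaker inhibition. In this assay compound 1 gives only a limit, > 211000 nM, so no number is known for it. Two related compounds give context. Compound 3 `CO/N=C(/N)c1ccc(-c2ccc(-c3ccc(C(=N)NOC)cc3)nc2)cc1` likewise reaches only a limit, > 166000 nM. Compound 2 `CONC(=N)c1ccc(-c2ccc(-c3ccc(C(=N)NOC)cc3)c(F)c2)cc1` gives 8500 nM, but it differs from compound 1 in more than one place, so its value cannot be tied to a single change. Compound 4 `N=C(NO)c1ccc(-c2ccc(-c3ccc(/C(N)=N\O)cc3)cc2F)cc1` differs from compound 1 by fluoro in place of hydrogen on an aromatic carbon. Among the compounds with values here, no single-change step has been measured here, so the size of the step is uncertain; the expectation is that it is small, estimated as an at least 1.4-fold lower number from compound 1 to compound 4 (0.14 log units; that floor lies within the scatter), with compound 4 staying near the limit. Compound 4 is therefore expected to give 150000 nM, between 30000 nM and 400000 nM.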

Compound 4, half-maximal inhibitory concentration: 29100 nM
Estimate against measurement, compound 4: 5.2-fold (0.71 log units) above; the whole stated range lies above it.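

Replacing hydrogen with fluoro at this position, ortho to a large group and meta to a large group, gives an at least 7.2-fold lower number from compound 1 to compound 4 (0.86 log units; beyond the scatter) in this assay. A single added atom on the core of compound 1 is therefore enough to produce a measurable number on this read-out. Compound 1 reaches only a limit, so the step is a floor and its true size stays unknown: the limit of > 211000 nM in this assay, at which 1 of the 4 values shown sits.

On these data alone, whether a chloro or a nitrile at this same position would shift the number as well remains open. So does whether fluoro at another place on this core would give a similar step.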